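Swapping the Chain on the Indole Nitrogen of Compound 1

This account rests on a few compounds, and the source may have more. Where it says the series, first, only, none or still open, it means among the compounds named here.

Of the compounds shown here, three have been measured in a functional assay on FaDu cells (Homo sapiens) for cytotoxicity, read by MTT assay, with a stated time of 72 h; a lower number here means that less compound is tolerated, a higher number that more compound is tolerated. Compound 1 `COc1ccc(NC(=O)C(=O)c2cn(CC(C)C)c3ccccc23)cn1` gives 317 nM, the highest of the three numbers. Compound 2 `COCCn1cc(C(=O)C(=O)Nc2ccc(OC)cc2)c2ccccc21` gives 59 nM, and compound 3 `COCCn1cc(C(=O)C(=O)Nc2ccnc(OC)c2)c2ccccc21` gives 235 nM. Between compound 1 and compound 3 the gap lies within the scatter, while compound 2 sits well apart from compound 1.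

Among the compounds with values here, the one step recorded between compounds that differ in a single place is a 4.0-fold higher number from compound 2 to compound 3 (0.60 log units; beyond the scatter), a modest change that concerns the aromatic group on the amide nitrogen, not the chain on the aromatic nitrogen of the shared core.

Compound 4 `COc1ccc(NC(=O)C(=O)c2cn(CCOC(C)C)c3ccccc23)cn1` differs from compound 1 by isopropoxymethyl in place of isopropyl on a saturated chain carbon bound to an aromatic nitrogen. Within the data shown here, no measured step touches this part of the molecule directly. The only hint is indirect: compound 3, which carries a short ether chain on the same aromatic nitrogen together with a different aromatic group on the amide, lies within the scatter of compound 1. On that basis the step of a 1.2-fold lower number from compound 1 to compound 4 (0.09 log units; within the scatter) is expected to stay within the scatter, in no particular direction. Compound 4 is therefore estimated at 260 nM in this assay, with a plausible range from 100 nM to 700 nM.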

Compound 4, concentration lethal to 50% of the cells: 211 nM
Beside the measured number, compound 4's estimate is 1.2-fold (0.09 log units) above it; the measured number falls inside the stated range.
By their numbers in this assay, from the lowest: compound 2; then compounds 4, 3 and 1 (each within the scatter of the next).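

Within the data shown here, this is the first comparison in which only the chain on the aromatic nitrogen changes while the rest of compound 1 stays fixed. In this assay, replacing isopropyl with isopropoxymethyl, which reads as isobutyl to 2-isopropoxyethyl when cut one bond further out, gives a 1.5-fold lower number from compound 1 to compound 4 (0.18 log units; within the scatter). At this position on this core, then, a longer chain that carries an ether oxygen and a hydrogen-bond acceptor leaves the number within the usual scatter, and no supporting measurement is available to explain this result.

The compounds shown leave open whether the oxygen in the chain has any bearing of its own on the number, a question that a 4-methylpentyl chain, with carbon in place of that oxygen, could help to settle. They also leave open whether the number would stay within the scatter with a chain ending in an amine or a carboxylic acid, since both the isobutyl and the 2-isopropoxyethyl chains carry no net charge.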